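Swapping an aryl amide for a morpholine amide

The compounds below may be only part of what the source reports. "The series", "measured", "known", "first", "only" and "open" are said of these compounds alone.

Three compounds share one core and differ only in the group on the amide nitrogen. Compound 1 `CC(=O)Oc1ccc(-c2ccc(F)cc2F)cc1C(=O)Nc1cccc(C)c1` gives 19% in a functional assay on the whole organism (strain Kunming) for inhibition, with Mus musculus as the target, in the writhing test, at a dose of 40 mg/kg by the oral route; on this read-out lower numbers stand for less inhibition and higher numbers for more inhibition at the one dose given (going by the name of the read-out). Compound 2 `CC(=O)Oc1ccc(-c2ccc(F)cc2F)cc1C(=O)Nc1ccccc1Cl` gives 11.7%, and compound 3 `CC(=O)Oc1ccc(-c2ccc(F)cc2F)cc1C(=O)Nc1ccc(Cl)cc1` gives 29.9%. On these numbers compound 3 stands highest; the step of a number 10.9 percentage points higher from compound 1 to compound 3 (beyond the scatter) and the step of a number 18.2 percentage points higher from compound 2 to compound 3 (beyond the scatter) both lie beyond the scatter, while a number 7.3 percentage points lower from compound 1 to compound 2 (within the scatter) does not.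

Compound 4 `CC(=O)Oc1ccc(-c2ccc(F)cc2F)cc1C(=O)NN1CCOCC1` has not yet been tested. Its change from compound 3 is morpholin-4-yl in place of 4-chlorophenyl on an amide-type nitrogen. Going by the values given here, every measured step so far exchanged one aromatic ring for another aromatic ring on that nitrogen, and the largest of them was modest. Among the compounds with values here, no measured pair shows what happens when a non-aromatic ring with two hetero atoms replaces the aromatic ring, so the known steps give little guidance for this change. With this in mind, a modest fall is expected, giving compound 4 an estimated 18% with a range of 5% to 35%, which would mean an expected step of a number 11.9 percentage points lower from compound 3 to compound 4 (beyond the scatter).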

Compound 4, a percentage reported as inhibition, in the whole organism at one dose (the size of the read-out at that dose, not a potency): 28.5%
Compound 4: middle estimate off by 10.5 percentage points, on the low side, and the stated range covers the measured number.
By their numbers in this assay, from the lowest: compounds 2, 1, 4 and 3 (each within the scatter of the next, the first and the last beyond it).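

At this amide-type nitrogen, the read-out in this assay does not depend on an aromatic ring: morpholin-4-yl, a non-aromatic ring with 2 hetero atoms, stands level with 4-chlorophenyl (a number 1.4 percentage points lower from compound 3 to compound 4 (within the scatter)). Against the other two aromatic groups, the picture splits: the 2-chlorophenyl compound is clearly set apart (a number 16.8 percentage points higher from compound 2 to compound 4 (beyond the scatter)), whereas the 3-methylphenyl compound is not (a number 9.5 percentage points higher from compound 1 to compound 4 (within the scatter)). Nothing available explains why such different rings read alike.

The compounds shown leave open whether the ring oxygen of morpholin-4-yl matters, a question that piperidin-1-yl, the same ring with carbon in that place, could answer. An open-chain group such as dimethylamino on this nitrogen would show whether any ring is needed at all.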